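The compounds below may be only part of what the source reports. "The series", "measured", "known", "first", "only" and "open" are said of these compounds alone.

Values in a functional assay on MCF7 cells (Homo sapiens) for antiproliferative activity, read by MTT assay, with a stated time of 48 h; on this read-out lower numbers stand for stronger inhibition and higher numbers for weaker inhibition:
compound 1 `COc1ccc(-c2nc(SCC(=O)c3sc(-c4ccccc4)nc3C)nc(N)c2C#N)cc1` gives 27200 nM
compound 2 `Cc1nc(-c2ccccc2)sc1C(=O)CSc1nc(N)c(C#N)c(-c2ccc(Cl)cc2)n1` gives 20200 nM
compound 3 `Cc1nc(-c2ccccc2)sc1C(=O)CSc1nc(N)c(C#N)c(-c2ccccc2)n1` gives 30100 nM

Compound 3 at 30100 nM lies within the scatter of both other compounds, so these three numbers give no real ranking.

The next structure, compound 4 `Cc1nc(-c2ccc(Cl)cc2)sc1C(=O)CSc1nc(N)c(C#N)c(-c2ccccc2)n1`, turns one phenyl of compound 3 into 4-chlorophenyl, with chloro in place of hydrogen on an aromatic carbon. The closest evidence is the same pair of groups exchanged on a different aromatic ring of the molecule: a 1.5-fold higher number from compound 2 to compound 3 (0.17 log units; within the scatter). Two further changes on that other ring were also small: a 1.3-fold lower number from compound 1 to compound 2 (0.13 log units; within the scatter) and a 1.1-fold higher number from compound 1 to compound 3 (0.04 log units; within the scatter). Among the compounds with values here, no measurement yet shows what a change on the ring altered in compound 4 does, so this evidence carries over only loosely. Even so, none of the three measured steps left the scatter, and no step beyond the scatter is expected in this assay. The estimated change is small: a 1.3-fold lower number from compound 3 to compound 4 (0.12 log units; within the scatter). For compound 4 the expected value is 23000 nM, with an estimated range from 10000 nM to 50000 nM.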

Compound 4, half-maximal inhibitory concentration: 25200 nM
Compound 4: the middle estimate sits 1.1-fold (0.04 log units) below what was measured; measured number inside the range.
By their numbers in this assay, from the lowest: compounds 2, 4, 1 and 3 (each within the scatter of the next).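

Within the data shown here, compound 1, compound 2 and compound 3 differ only on one aromatic ring, so compound 4 gives the first look at the other phenyl, where a chloro para to a large group produces a 1.2-fold lower number from compound 3 to compound 4 (0.08 log units; within the scatter) in this assay. The same exchange of groups on the first ring, read in the opposite direction, gave a 1.5-fold higher number from compound 2 to compound 3 (0.17 log units; within the scatter), so chloro in place of hydrogen has stayed within the scatter on both rings, and this position shows no sensitivity to that one small change. No independent measurement bears on why this change has so little effect on the number.

Going by these compounds, a single substituent says little about this position as a whole, so it remains open whether a carboxylic acid, a dimethylamino group or a longer chain in the place of the chloro would move the number beyond the scatter. Also open is whether chloro on both aromatic rings at once would do more than either single change, since the shown compounds carry it on one ring at a time.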